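This account rests on a few compounds, and the source may have more. Where it says the series, first, only, none or still open, it means among the compounds named here.

Working notes on the series. Within the data shown here, compound 1, `COc1ccc(/C=C/C(=O)c2cccc(-c3cccc(F)c3)c2)cc1`, is the reference point; in a functional assay on MCF7 cells (Homo sapiens) for cytotoxicity, read by sulforhodamine B assay, with a stated time of 48 h (on this read-out lower numbers stand for stronger inhibition and higher numbers for weaker inhibition), compound 1 gives 3080 nM, the low end of the three numbers so far. Compound 2, `COc1ccc(/C=C/C(=O)c2cccc(-c3cccc(F)c3)c2)cc1OC`, gives 4620 nM, and the step of a 1.5-fold higher number from compound 1 to compound 2 (0.18 log units; within the scatter) adds a methoxy on an aromatic carbon. Compound 3, `O=C(/C=C/c1ccc(Cl)cc1)c1cccc(-c2cccc(F)c2)c1`, gives 18200 nM, and the step of a 5.9-fold higher number from compound 1 to compound 3 (0.77 log units; beyond the scatter) puts a chloro in place of the methoxy.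

Compound 4, `COc1ccc(/C=C/C(=O)c2cccc(-c3ccc(F)cc3)c2)cc1`, differs from compound 1 only in the fluorophenyl: 4-fluorophenyl in place of 3-fluorophenyl on an aromatic carbon. Neither measured step touches this ring; both alter the methoxyphenyl side of the core of compound 1, so they bear on compound 4 only in showing that the shared core tolerates changes at the other end without large shifts. No step beyond the scatter is therefore expected in this assay for moving the fluorine within the ring.

The expected step of a 1.1-fold higher number from compound 1 to compound 4 (0.06 log units; within the scatter) is essentially flat, and compound 4 is estimated at 3500 nM, within 1500 nM to 8500 nM.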

Compound 4, half-maximal inhibitory concentration: 16400 nM
Compound 4: middle estimate off by 4.7-fold (0.67 log units), on the low side; measured number above the stated range.
By their numbers in this assay, from the lowest: compounds 1 and 2 (each within the scatter of the next); then compounds 4 and 3 (each within the scatter of the next).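

In this assay, the fluorophenyl end of the shared core proves sensitive: the swap of 3-fluorophenyl for 4-fluorophenyl gives a 5.3-fold higher number from compound 1 to compound 4 (0.73 log units; beyond the scatter), although the two groups have the same atoms and the same counts under comparison. Among these compounds, the earlier steps changed only the methoxyphenyl side, so this is the first reading at this position, and it shows that the placement of the fluorine alone moves the number beyond the scatter, towards weaker inhibition. No measured evidence bears on what lies behind this step.

Going by these compounds, it remains open whether a plain phenyl, or an amine or carboxylic acid on this ring, would read closer to compound 1 or to compound 4. On these data alone, whether the same step recurs with the chloro group of compound 3 at the other end is also open.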